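Replacing the dichlorophenyl arm with 4-hydroxyphenyl

A few compounds are considered here, and "the series" means these few. Any claim that something is new, unique, unknown or untested is made for them only; others in the source may bear on it.

Compound 3 `O=C1/C(=C/c2c(Cl)cccc2Cl)c2ccccc2N1c1c(Cl)cccc1Cl` sits at the top of the set. In a functional assay on SW-620 cells (Homo sapiens) for cytotoxicity, read by MTT assay, with a stated time of 3 days (on this read-out lower numbers stand for an effect already at smaller amounts and higher numbers for an effect only at larger amounts of compound), compound 3 gives only a limit, > 100 ug/mL. Compound 1 `O=C1/C(=C/c2ccccc2Cl)c2ccccc2N1c1c(Cl)cccc1Cl` gives 15 ug/mL in this assay, and compound 2 `O=C1/C(=C/c2ccc(Cl)cc2)c2ccccc2N1c1c(Cl)cccc1Cl` gives 100 ug/mL. The measured steps run one way: a 6.7-fold higher number from compound 1 to compound 2 (0.82 log units; beyond the scatter), an at least 6.6-fold higher number from compound 1 to compound 3 (0.82 log units; beyond the scatter), and a number no lower from compound 2 to compound 3 (the limit leaves the size open). Compound 4 `O=C1/C(=C/c2ccc(O)cc2)c2ccccc2N1c1c(Cl)cccc1Cl` differs from compound 3 by 4-hydroxyphenyl in place of 2,6-dichlorophenyl on a double-bonded chain carbon bound to a double-bonded ring carbon. Among the measured compounds shown here, no measured step exchanges a chloro-bearing ring for a hydroxy-bearing one; the nearest guide is compound 2, whose 4-chlorophenyl ring gave 100 ug/mL. Compound 4 is therefore expected to leave the limit, an at least 1.6-fold lower number from compound 3 to compound 4 (0.22 log units; that floor lies within the scatter), though a limit may again be reported. The estimate for compound 4 in this assay is 60 ug/mL, ranging from 15 ug/mL to 150 ug/mL.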

Compound 4, concentration for half-maximal effect: 50 ug/mL
Compound 4: the middle estimate sits 1.2-fold (0.08 log units) above what was measured; the measured number falls inside the stated range.
By their numbers in this assay, from the lowest: compound 1; then compounds 4 and 2 (each within the scatter of the next).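

In this assay, hydroxy in place of chloro on an aromatic carbon gives a 2.0-fold lower number from compound 2 to compound 4 (0.30 log units; within the scatter), so this exchange on the ring is not separated from no change. 4-hydroxyphenyl in place of 2,6-dichlorophenyl gives an at least 2.0-fold lower number from compound 3 to compound 4 (0.30 log units; that floor lies within the scatter), a step of which only the floor can be read. 4-hydroxyphenyl in place of 2-chlorophenyl gives a 3.3-fold higher number from compound 1 to compound 4 (0.52 log units; beyond the scatter), so compound 1 stays apart from compound 4.

From the compounds shown here alone, how an amine or a carboxylic acid on this ring would read remains open. Compound 3 remains a limit, so the full size of its step stays open: the limit of > 100 ug/mL in this assay, at which 1 of the 4 values shown sits.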